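The source may hold more compounds than are shown below. What is called first, only, known or untested is meant among the compounds shown, and "the series" means these compounds.

Measured so far in an in vitro assay on SH-EP1 cells for displacement of a labelled ligand from Neuronal acetylcholine receptor; alpha4/beta2 (Homo sapiens); a lower number here means a stronger inhibitor, a higher number a weaker inhibitor:
compound 1 `C1=C(c2cncc(OCc3ccccc3)c2)CC2CNCC1C2`, which gives 0.7 nM
compound 2 `Clc1ccc(C2=CC3CNCC(C2)C3)cn1`, which gives 0.4 nM
compound 3 `COc1ccccc1Oc1cncc(C2=CC3CNCC(C2)C3)c1`, which gives 1 nM

Compound 3 carries the highest of the three numbers in this assay. Its nearest neighbour is compound 1, whose number lies within the scatter of it; only compound 2 sits apart, with a number lower by a margin beyond the scatter.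

Compound 4 `Clc1ccc(Oc2cncc(C3=CC4CNCC(C3)C4)c2)cc1` is not yet measured. The change from compound 3 is 4-chlorophenyl in place of 2-methoxyphenyl on an oxygen on an aromatic ring. For the measured compounds named here, one measured step bears on this position: a 1.4-fold higher number from compound 1 to compound 3 (0.15 log units; within the scatter). That exchange of the group on the oxygen, from benzyl to 2-methoxyphenyl, left the number where it was. Going by the values given here, no measured step shows a chlorine on this group, so the direction of any shift is open. Among the compounds with values here, on the single relevant step the expectation is no change beyond the scatter.

Compound 4 is therefore estimated at 1 nM, with a range of 0.4 nM to 2.5 nM. The expected step is no change at the digits printed from compound 3 to compound 4 (within the scatter).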

Compound 4, inhibition constant: 1.9 nM
The estimate for compound 4 lay 1.9-fold (0.28 log units) below the measured number, and the stated range covers the measured number.
By their numbers in this assay, from the lowest: compounds 2, 1, 3 and 4 (each within the scatter of the next, the first and the last beyond it).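

In this assay, replacing the 2-methoxyphenyl group with 4-chlorophenyl gives a 1.9-fold higher number from compound 3 to compound 4 (0.28 log units; within the scatter), so this exchange on the oxygen is not resolved as a change. Against the benzyl group, the same 4-chlorophenyl gives a 2.7-fold higher number from compound 1 to compound 4 (0.43 log units; beyond the scatter), the only step at this position that lies beyond the scatter, and it is a modest one. No evidence is available to account for either step.

Going by these compounds, whether the step beyond the scatter follows from the chlorine or from the aromatic ring standing directly on the oxygen stays open: a plain phenyl or a 4-chlorobenzyl group on this oxygen would separate the two. Also open, on these data alone, is whether an amine or a carboxylic acid on that ring, or a longer chain in place of benzyl, would keep the number in this range.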